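The source may hold more compounds than are shown below. What is called first, only, known or untested is meant among the compounds shown, and "the series" means these compounds.

Measured so far in a functional assay on A549 cells (Homo sapiens) for antiproliferative activity, read by MTT assay, with a stated time of 72 h; on this read-out lower numbers stand for stronger inhibition and higher numbers for weaker inhibition:
compound 1 `COc1ccc(N2C(=O)COc3ccc(-c4cnc5ccccc5c4)cc32)cc1` — > 40000 nM
compound 2 `O=C1COc2ccc(-c3cnc(Cl)c(NS(=O)(=O)c4ccc(F)cc4)c3)cc2N1c1ccc(F)cc1` — 22300 nM

On these numbers compound 1 stands at the limit of > 40000 nM in this assay, at which 1 of the 2 values shown sits, a limit of the assay rather than a measured number. In this assay compound 2 gives 22300 nM, a number inside the measured window, and that is all the two values show of the pair.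

Compound 3 `O=C1COc2ccc(-c3cnc4ccccc4c3)cc2N1C1CCCCC1` has not yet been measured. It differs from compound 1 in one place: cyclohexyl in place of 4-methoxyphenyl on an amide-type nitrogen in a ring. Because compound 1 offers only (the limit of > 40000 nM in this assay, at which 1 of the 2 values shown sits), any step from it is anchored at one end only. The author expects no shift in this assay beyond the usual scatter, with a step from compound 1 to compound 3 estimated at an at least 1.1-fold lower number from compound 1 to compound 3 (0.05 log units; that floor lies within the scatter). Compound 3 is therefore estimated at 35000 nM, in a range from 8000 nM to 120000 nM, with a fair chance that only a limit is reported again.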

Compound 3, half-maximal inhibitory concentration: > 40000 nM
Compound 3: no number, only a limit (the forecaster's own chance of this, stated with the estimate: 50%); middle value at least 1.1-fold (0.05 log units) away from the limit.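

For the compounds shown here, compound 3, like compound 1, gives only a limit of the assay and not a number, so no step between the two can be read: the limit of > 40000 nM in this assay, at which 2 of the 3 values shown sit. The compounds shown leave open whether cyclohexyl in place of 4-methoxyphenyl shifts the result in this assay at all.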